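Cyclohexyl to tert-Butyl on a Spirocyclic Amide Scaffold

The source may report more compounds than this note shows. Statements on the series, on what has been measured and on what is new or still open speak of the compounds shown alone.

Measured compounds:
compound 1, `CC1CCCN(C(=O)CN2CN(c3ccccc3)C3(CCN(C(=O)c4ccc(C5CCCCC5)cc4)CC3)C2=O)C1`: 3600 nM
compound 2, `CC1CCCN(C(=O)CN2CN(c3ccccc3)C3(CCN(C(=O)c4ccc(C(C)(C)C)cc4)CC3)C2=O)C1`: 12000 nM
compound 3, `CS(=O)(=O)NCCCNC(=O)CN1CN(c2ccccc2)C2(CCN(C(=O)c3ccc(C4CCCCC4)cc3)CC2)C1=O`: 3800 nM

All three were tested in an assay on HEK293 cells for displacement of a labelled ligand from NPC1-like intracellular cholesterol transporter 1 (Homo sapiens); a higher number here means a weaker inhibitor, a lower number a stronger inhibitor. Compound 1 and compound 2 differ only by tert-butyl in place of cyclohexyl on an aromatic carbon; this change gave a 3.3-fold higher number from compound 1 to compound 2 (0.52 log units; beyond the scatter). Compound 3 differs from compound 1 elsewhere, by (3-(methanesulfonamido)propyl)amino in place of 3-methylpiperidin-1-yl on a carbonyl carbon, and that change gave a 1.1-fold higher number from compound 1 to compound 3 (0.02 log units; within the scatter). Compound 4, `CC(C)(C)c1ccc(C(=O)N2CCC3(CC2)C(=O)N(CC(=O)NCCCNS(C)(=O)=O)CN3c2ccccc2)cc1`, is not yet measured; it differs from compound 3 by tert-butyl in place of cyclohexyl on an aromatic carbon, the same change as between compound 1 and compound 2, at an identical place. The step to compound 4 in this assay is expected to be a 3.2-fold higher number from compound 3 to compound 4 (0.50 log units; beyond the scatter), because the same change earlier gave a 3.3-fold higher number from compound 1 to compound 2 (0.52 log units; beyond the scatter) on a core whose value lies within the scatter of compound 3. Compound 4 is estimated at 12000 nM, with a range from 6000 nM to 25000 nM.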

Compound 4, half-maximal inhibitory concentration: 10400 nM
Compound 4: the middle estimate sits 1.2-fold (0.06 log units) above what was measured; the range from low to high includes it.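

Putting tert-butyl in place of cyclohexyl weakened binding again in this assay, with a 2.7-fold higher number from compound 3 to compound 4 (0.44 log units; beyond the scatter), and the size of the loss held across the two cores: the same change on two cores in this assay, a 3.3-fold higher number (0.52 log units; beyond the scatter) from compound 1 to compound 2 and a 2.7-fold higher number (0.44 log units; beyond the scatter) from compound 3 to compound 4, 1.2-fold (0.09 log units) apart, within the scatter of two such steps. Swapping 3-methylpiperidin-1-yl for (3-(methanesulfonamido)propyl)amino gave a 1.2-fold lower number from compound 2 to compound 4 (0.06 log units; within the scatter), which agrees with its earlier result: the same change on two cores in this assay, a 1.1-fold higher number (0.02 log units; within the scatter) from compound 1 to compound 3 and a 1.2-fold lower number (0.06 log units; within the scatter) from compound 2 to compound 4, 1.2-fold (0.09 log units) apart, within the scatter of two such steps. In these four compounds, each change can therefore be carried from one core to the other with a similar result, but a single pair of cores does not show that this holds across the series, or why.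

As far as these compounds go, it remains open how a methyl or a cyclopentyl group on that aromatic carbon would behave. The same is true of an amine or a carboxylic acid in place of the methanesulfonamido group.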